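A few compounds are considered here, and "the series" means these few. Any claim that something is new, unique, unknown or untested is made for them only; others in the source may bear on it.

Measured compounds in a functional assay on BGC-823 cells (Homo sapiens) for inhibition, read by MTT assay, with a stated time of 72 h; on this read-out higher numbers stand for weaker inhibition and lower numbers for stronger inhibition:
compound 1 `Cc1cc(N2CC[C@@H](C)[C@@H](N(C)c3ncnc4[nH]ccc34)C2)n2nc(SCc3nc4ccccc4[nH]3)nc2n1`; compound 2 `Cc1cc(N2CC[C@@H](C)[C@@H](N(C)c3ncnc4[nH]ccc34)C2)n2nc(SCc3ccccc3Br)nc2n1`; compound 3 `Cc1cc(N2CC[C@@H](C)[C@@H](N(C)c3ncnc4[nH]ccc34)C2)n2nc(SCC3CCCCC3)nc2n1`.

Compound 1 gives only a limit, > 100000 nM, in this assay (the limit of > 100000 nM in this assay, at which 1 of the 3 values shown sits). Compound 2 gives 81100 nM and compound 3 gives 16300 nM. Compound 2 thus stands highest of the two numbers, with compound 3 the nearest value. Steps: an at least 1.2-fold lower number from compound 1 to compound 2 (0.09 log units; that floor lies within the scatter); an at least 6.1-fold lower number from compound 1 to compound 3 (0.78 log units; beyond the scatter); a 5.0-fold lower number from compound 2 to compound 3 (0.70 log units; beyond the scatter).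

Compound 4 `C#CSc1nc2nc(C)cc(N3CC[C@@H](C)[C@@H](N(C)c4ncnc5[nH]ccc45)C3)n2n1` differs from compound 2 by ethynyl in place of 2-bromobenzyl on a sulfur. Going by the values given here, only the step from compound 2 to compound 3 bears on this, since it also exchanges the group on the sulfur, and it gave a modest lowering; whether a much smaller ethynyl behaves like cyclohexyl is open. A small lowering is expected, a 2.0-fold lower number from compound 2 to compound 4 (0.31 log units; beyond the scatter), within wide bounds. Compound 4 is estimated at 40000 nM, range 10000 nM to 150000 nM.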

Compound 4, half-maximal inhibitory concentration: 62100 nM
The estimate for compound 4 lay 1.6-fold (0.19 log units) below the measured number; the range from low to high includes it.
By their numbers in this assay, from the lowest: compound 3; then compounds 4 and 2 (each within the scatter of the next). At a limit, above all of these: compound 1.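

Ethynyl in place of 2-bromobenzyl on the sulfur removes the ring, yet the two compounds stay within the scatter of each other, with a 1.3-fold lower number from compound 2 to compound 4 (0.12 log units; within the scatter). Cyclohexylmethyl alone stands apart, with a 3.8-fold higher number from compound 3 to compound 4 (0.58 log units; beyond the scatter), so the stronger inhibition at this position rests on compound 3 only. Compound 1 stands at a limit: the limit of > 100000 nM in this assay, at which 1 of the 4 values shown sits. The exchange of (1H-benzimidazol-2-yl)methyl for ethynyl therefore gives only a floor, an at least 1.6-fold lower number from compound 1 to compound 4 (0.20 log units; that floor lies within the scatter), and its true size cannot be read.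

Open, going by these compounds, is whether the gain needs a saturated ring, which a straight hexyl chain could test. Also open, on these data alone, is how an amine or a carboxylic acid on the sulfur-bound chain would read.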